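A few compounds are considered here, and "the series" means these few. Any claim that something is new, unique, unknown or untested is made for them only; others in the source may bear on it.

Measured in a functional assay on HL-60 cells (Homo sapiens) for antiproliferative activity, read by XTT assay, with a stated time of 72 h; on this read-out higher numbers stand for weaker inhibition and lower numbers for stronger inhibition:
compound 1 `CSc1ncnc2c1c(-c1ccccc1)cn2[C@@H]1O[C@H](CO)[C@@H](O)[C@H]1O`: > 20000 nM, a limit
compound 2 `CNc1ncnc2c1c(-c1ccco1)cn2[C@@H]1O[C@H](CO)[C@@H](O)[C@H]1O`: 620 nM
compound 3 `CNc1ncnc2c1c(-c1ccccc1)cn2[C@@H]1O[C@H](CO)[C@@H](O)[C@H]1O`: > 20000 nM, a limit

Compound 3 gives only a limit, and it sits at the limit of > 20000 nM in this assay, at which 2 of the 3 values shown sit. Compound 4 `CNc1ncnc2c1c(I)cn2[C@@H]1O[C@H](CO)[C@@H](O)[C@H]1O` carries iodo in place of phenyl on an aromatic carbon. Among the compounds with values here, the one readable step at that carbon is an at least 32-fold higher number from compound 2 to compound 3 (1.50 log units; beyond the scatter), a large step. The other step, a step that the two limits leave unreadable from compound 1 to compound 3, concerns a different place and gives no size. Iodo itself is untested in this series, so the transfer from furan-2-yl is uncertain. A large move to a lower number is still expected in this assay, given compound 2 at 620 nM. The expected change is an at least 13-fold lower number from compound 3 to compound 4 (1.12 log units; beyond the scatter). The estimate for compound 4 is 1500 nM, with an expected range of 150 nM to 12000 nM.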

Compound 4, half-maximal inhibitory concentration: > 20000 nM
Compound 4: no number, only a limit; the forecaster's own chance of this, stated with the estimate: 25%; middle value at least 13-fold (1.12 log units) from the limit.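

In this assay, iodo in place of furan-2-yl gives an at least 32-fold higher number from compound 2 to compound 4 (1.50 log units; beyond the scatter) at this aromatic carbon. A single iodine atom, like phenyl, therefore leaves no readable value, and among the groups shown only furan-2-yl gives a number here. Compound 4 gives only a limit, so the step from compound 3 cannot be read, and the limit is shared across most of the set: the limit of > 20000 nM in this assay, at which 3 of the 4 values shown sit. On these data alone, it remains open whether thiophen-2-yl or an amine at this carbon gives a number, and whether furan-2-yl keeps its value with methylsulfanyl in place of methylamino.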